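Acetyl to dimethylcarbamoyl on the pyrrolidine alkyne amide

A few compounds are considered here, and "the series" means these few. Any claim that something is new, unique, unknown or untested is made for them only; others in the source may bear on it.

Measured so far:
compound 1: `CC(=O)N(C)C(C)C#CCn1ccnc1C` — > 100 mg/kg
compound 2: `CC(=O)N(C)CC#CCN1CCCC1` — 0.55 mg/kg

Both compounds have been run in a functional assay on the whole organism for agonist activity, with Mus musculus as the target; on this read-out higher numbers stand for an effect only at larger amounts of compound and lower numbers for an effect already at smaller amounts. For compound 1 the value > 100 mg/kg is a limit of the assay, not a number, as the record shows at the limit of > 100 mg/kg in this assay, at which 1 of the 2 values shown sits. Going by the values given here, compound 2 gives 0.55 mg/kg in this assay, and among the two values shown it is the only number, so compound 2 stands as the single quantified point of the series.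

Compound 3, `CN(C)C(=O)N(C)CC#CCN1CCCC1`, differs from compound 2 in one place:
dimethylamino in place of methyl on a carbonyl carbon

Among the compounds with values here, no step between two measured compounds is available to gauge this change, and nothing in the measured pair shows what a larger acyl group on the amide-type nitrogen does. The working expectation for compound 3 is a step of a 2.7-fold higher number from compound 2 to compound 3 (0.44 log units; beyond the scatter) in this assay, a mild weakening that may still sit within the usual scatter. On that basis compound 3 is estimated at 1.5 mg/kg in this assay, with a range of 0.4 mg/kg to 6 mg/kg.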

Compound 3, dose for half-maximal effect: > 10 mg/kg
Compound 3: only a limit was reported; the forecaster's own chance of this, stated with the estimate: 10%; middle value at least 6.6-fold (0.82 log units) away from the limit.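

In this assay, going by these compounds alone, dimethylamino in place of methyl on a carbonyl carbon gives an at least 18-fold higher number from compound 2 to compound 3 (1.25 log units; beyond the scatter), the first step that can be read between compounds differing in one place. This position, on a carbonyl carbon whose other neighbour is the amide-type nitrogen, is therefore not indifferent to the change from acetyl to dimethylcarbamoyl: the effect seen at low doses with the acetyl group of compound 2 is not seen with the dimethylcarbamoyl group over the doses that the result for compound 3 covers. The result for compound 3 is a limit of the assay and not a number, so the step gives only a lower bound on the change: the limit of > 10 mg/kg in this assay, at which 1 of the 3 values shown sits.

The compounds shown do not separate the contribution of the added nitrogen from that of the two added carbons, which ethyl or amino on the same carbonyl carbon would begin to address. As far as these compounds go, it also remains open whether any group larger than methyl can stand at this position and keep the effect, with methoxy or cyclopropyl as further candidates.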